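From Cyclohexyl to 4-Methylphenyl on the Ring Nitrogen

The source may hold more compounds than are shown below. What is called first, only, known or untested is meant among the compounds shown, and "the series" means these compounds.

Compound 3 `O=C1COc2ccc(-c3cnc(Cl)c(NS(=O)(=O)c4ccc(F)cc4)c3)cc2N1C1CCCCC1` has been measured in a functional assay on MCF7 cells (Homo sapiens) for antiproliferative activity, read by MTT assay, with a stated time of 72 h (on this read-out lower numbers stand for stronger inhibition and higher numbers for weaker inhibition), and reaches only the limit of the assay, > 40000 nM. Compound 2 `O=C1COc2ccc(-c3cnc(Cl)c(NS(=O)(=O)c4ccc(F)cc4)c3)cc2N1c1ccccc1`, carrying phenyl on the same nitrogen, likewise gives only a limit in this assay, > 40000 nM. Among the measured compounds shown here, the one measured step that touches this nitrogen, a step that the two limits leave unreadable from compound 2 to compound 3, cannot be sized because of the limit of > 40000 nM in this assay, at which 2 of the 3 values shown sit. For the measured compounds named here, compound 1 `COc1ncc(-c2ccc3c(c2)N(c2ccc(C)cc2)C(=O)CO3)cc1NS(=O)(=O)c1ccc(F)cc1` carries 4-methylphenyl on that nitrogen but differs from compound 4 at another site, methoxy in place of chlorine, and in this assay compound 1 gives 15400 nM; no single step connects it to compound 3.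

Compound 4 `Cc1ccc(N2C(=O)COc3ccc(-c4cnc(Cl)c(NS(=O)(=O)c5ccc(F)cc5)c4)cc32)cc1` differs from compound 3 in one place: 4-methylphenyl in place of cyclohexyl on an amide-type nitrogen in a ring. Going by the values given here, no measured step fixes the size of this change. Compound 1 at least shows that a compound bearing 4-methylphenyl on this nitrogen can return a readable value, 15400 nM. Compound 4 is therefore expected to lie close to the limit, estimated at 35000 nM with a range from 12000 nM to 90000 nM. The expected step from compound 3 is an at least 1.1-fold lower number from compound 3 to compound 4 (0.05 log units; that floor lies within the scatter), which the limit of compound 3 leaves uncertain.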

Compound 4, half-maximal inhibitory concentration: 32600 nM
Compound 4: the middle estimate sits 1.1-fold (0.03 log units) above what was measured, and the stated range covers the measured number.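

Among the chloro compounds shown, compound 4 alone returns a readable number in this assay, so 4-methylphenyl on this nitrogen gives a measured value where phenyl and cyclohexyl give only limits. Placing 4-methylphenyl in place of cyclohexyl gives an at least 1.2-fold lower number from compound 3 to compound 4 (0.08 log units; that floor lies within the scatter), and methyl in place of hydrogen on the aromatic carbon gives an at least 1.2-fold lower number from compound 2 to compound 4 (0.08 log units; that floor lies within the scatter); the true size of neither step can be read because compound 2 and compound 3 each stand at a limit: the limit of > 40000 nM in this assay, at which 2 of the 4 values shown sit.

With 4-methylphenyl held on the nitrogen, chloro in place of methoxy gives a 2.1-fold higher number from compound 1 to compound 4 (0.33 log units; beyond the scatter), a modest step at the other site. The compounds shown leave open whether a benzyl group or a chain ending in an amine on this nitrogen would move the number further. They also leave open whether the exchange of chloro and methoxy would give a similar step with phenyl or cyclohexyl on the nitrogen.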